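This account rests on a few compounds, and the source may have more. Where it says the series, first, only, none or still open, it means among the compounds named here.

Measured in a functional assay on HT-29 cells (Homo sapiens) for inhibition, read by sulforhodamine B assay, with a stated time of 72 h; a lower number here means a stronger inhibitor, a higher number a weaker inhibitor:
- compound 1 `CCCNC(=C\C(=O)/C=C/c1ccc(O)c(OC)c1)/C=C/c1ccc(O)c(OC)c1`: > 25000 nM (a limit of the assay)
- compound 2 `C=CCNC(=C\C(=O)/C=C/c1ccc(O)c(OC)c1)/C=C/c1ccc(O)c(OC)c1`: 24600 nM
- compound 3 `CC(C)CNC(=C\C(=O)/C=C/c1ccc(O)cc1)/C=C/c1ccc(O)cc1`: 22500 nM

Compound 2 lies within the scatter of compound 3 at 22500 nM, so the two cannot be ordered. Compound 1 gives only a limit, (the limit of > 25000 nM in this assay, at which 1 of the 3 values shown sits).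

Compound 4 `COc1cc(/C=C/C(=O)/C=C(/C=C/c2ccc(O)c(OC)c2)NCC(C)C)ccc1O` follows from compound 2 by isopropyl in place of vinyl on a saturated chain carbon bound to an amine nitrogen. For the measured compounds named here, the one measured step at this place, an at least 1.0-fold lower number from compound 1 to compound 2 (0.00 log units; that floor lies within the scatter), shows no change beyond the scatter. Compound 3 also carries isobutylamino, on a different core, and its value is of the same size as that of compound 2.

No step beyond the scatter is therefore expected in this assay, with the estimated step being a 1.1-fold lower number from compound 2 to compound 4 (0.05 log units; within the scatter). For compound 4 the expected value is 22000 nM, with an estimated range of 12000 nM to 35000 nM.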

Compound 4, half-maximal inhibitory concentration: 24000 nM
Estimate against measurement, compound 4: 1.1-fold (0.04 log units) below, within the range that was stated.
By their numbers in this assay, from the lowest: compounds 3, 4 and 2 (each within the scatter of the next). At a limit, above all of these: compound 1.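

In this assay, isobutylamino in place of allylamino on the shared core gives a 1.0-fold lower number from compound 2 to compound 4 (0.01 log units; within the scatter) within the scatter, so the loss of the chain double bond and the added branch leave no readable mark at this place. Methyl in place of hydrogen on a saturated chain carbon bound to two saturated chain carbons gives an at least 1.0-fold lower number from compound 1 to compound 4 (0.01 log units; that floor lies within the scatter) as a floor only, and compound 1 stands at a limit: the limit of > 25000 nM in this assay, at which 1 of the 4 values shown sits.

On these data alone, whether a terminal amine, a carboxylic acid or a longer chain here would give a number clear of the scatter stays open.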